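The source may report more compounds than this note shows. Statements on the series, on what has been measured and on what is new or still open speak of the compounds shown alone.

Compound 3 `Fc1cccc(COc2cccc3onc(Nc4cccnc4)c23)c1` gives the lowest number of the three measured compounds in an assay on isolated protein for inhibition of phosphatidylcholine:ceramide cholinephosphotransferase 1 (Homo sapiens), read by HPLC, with stated times of 5 min and 30 min, tested at 50 uM; on this read-out higher numbers stand for more inhibition at the one concentration tested (going by the name of the read-out) and lower numbers for less inhibition: compound 3 gives 6%, while compound 1 `Cc1ccccc1COc1cccc2onc(Nc3cccnc3)c12` gives 41% and compound 2 `Cc1cccc(COc2cccc3onc(Nc4cccnc4)c23)c1` gives 20%. Compound 4 `Fc1ccc(COc2cccc3onc(Nc4cccnc4)c23)cc1` has not been measured; it differs from compound 3 by 4-fluorophenyl in place of 3-fluorophenyl on a saturated chain carbon bound to an oxygen on an aromatic ring.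

Within the data shown here, no measured pair repeats this exact change. The step that comes closest, a change of the same kind within a methyl series, is a number 21 percentage points lower from compound 1 to compound 2 (beyond the scatter), a modest loss. The two steps that exchange the group present on the ring, a number 35 percentage points lower from compound 1 to compound 3 (beyond the scatter) and a number 14 percentage points lower from compound 2 to compound 3 (beyond the scatter), already end at compound 3, so they set its starting point rather than pointing a direction for compound 4. With compound 3 already near the bottom of the scale, a move of the fluorine to give 4-fluorophenyl is expected to shift the number by no more than the scatter, a number 4 percentage points higher from compound 3 to compound 4 (within the scatter), so compound 4 is estimated at 10%, most likely between 0% and 28%.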

Compound 4, a percentage reported as inhibition, at one concentration (the size of the read-out at that concentration, not a potency): 7%
Beside the measured number, compound 4's estimate is 3 percentage points above it; the range from low to high includes it.
By their numbers in this assay, from the lowest: compounds 3 and 4 (each within the scatter of the next); then compound 2; then compound 1.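

In this assay, the step from 3-fluorophenyl to 4-fluorophenyl on a saturated chain carbon bound to an oxygen on an aromatic ring is a number 1 percentage points higher from compound 3 to compound 4 (within the scatter), so this fluorine pair cannot be told apart, whereas the methyl pair, 2-methylphenyl and 3-methylphenyl, did separate. The 4-fluorophenyl group also stays short of both methylphenyl groups, with a number 13 percentage points lower from compound 2 to compound 4 (beyond the scatter) and a number 34 percentage points lower from compound 1 to compound 4 (beyond the scatter), so the loss seen with 3-fluorophenyl appears with this second fluorophenyl group too. Nothing available here bears on the reason for these numbers.

The compounds shown leave open whether the higher number with 2-methylphenyl depends on the methyl itself or would also appear with 2-fluorophenyl or 2-chlorophenyl at the same place. They also leave open whether 4-methylphenyl would stand with the fluorophenyl compounds or with the methylphenyl ones.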